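The source may hold more compounds than are shown below. What is called first, only, known or untested is meant among the compounds shown, and "the series" means these compounds.

For the measured compounds named here, compound 2 `O=C(Nc1cccc(-c2nc3ccccc3s2)c1)c1cc([N+](=O)[O-])c(O)cc1Cl` stands highest of the two numbers so far in an ADME assay for permeability, using PAMPA, at pH 7.4; a higher number here means that the compound crosses the layer faster, a lower number that the compound crosses the layer more slowly: compound 2 gives 307 10^-6 cm/s, whereas compound 1 `COc1cc(Cl)c(C(=O)Nc2cccc(-c3nc4ccccc4s3)c2)cc1[N+](=O)[O-]` gives 12 10^-6 cm/s. Going by the values given here, the only measured step is a 26-fold higher number from compound 1 to compound 2 (1.41 log units; beyond the scatter), a large one. Compound 3 `O=C(O)COc1cc(Cl)c(C(=O)Nc2cccc(-c3nc4ccccc4s3)c2)cc1[N+](=O)[O-]` follows from compound 2 by carboxymethyl in place of hydrogen on an oxygen on an aromatic ring. Among the compounds with values here, no measured step covers this exchange; the single step in hand concerns a different substituent on the same oxygen, and it only shows that this position moves the number strongly. A large downward step is expected, a 77-fold lower number from compound 2 to compound 3 (1.89 log units; beyond the scatter). Compound 3 is therefore estimated at 4 10^-6 cm/s, within 0.3 10^-6 cm/s to 40 10^-6 cm/s.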

Compound 3, apparent permeability in the ADME assay: < 1 10^-6 cm/s
Compound 3 ended at the assay's limit; the forecaster's own chance of this, stated with the estimate: 15%; middle value at least 4.0-fold (0.60 log units) from the limit.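

At this oxygen, the ADME assay now has a group that sits under both hydrogen and methyl: an at least 300-fold lower number from compound 2 to compound 3 (2.48 log units; beyond the scatter), and with the carboxy added to the methyl group, an at least 12-fold lower number from compound 1 to compound 3 (1.07 log units; beyond the scatter). Both steps end on a limit, so they give only a minimum size. In a physicochemical assay for solubility, read by spectrophotometry, in phosphate buffer, measured as kinetic solubility, with a stated time of 18 h, at pH 7.4 (a lower number here means a less soluble compound, a higher number a more soluble compound), compound 2 gives 2200 nM and compound 3 gives 6700 nM, a smaller shift in the opposite direction.

Open, on these data alone, is how far under the limit compound 3 lies. Also open, as far as these compounds go, is how a methyl ester, a primary amide or an amine on a longer chain at this oxygen would read in the ADME assay.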